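Solubility Outlook for an Amine-Bearing Analogue

This account rests on a few compounds, and the source may have more. Where it says the series, first, only, none or still open, it means among the compounds named here.

Of the compounds shown here, three sharing one core have been measured in a physicochemical assay for solubility, read by chemiluminescence, measured as kinetic solubility; a lower number here means a less soluble compound, a higher number a more soluble compound. Compound 1 `CC(=O)NCc1cccc(Cn2nc(NS(=O)(=O)c3ccc(Cl)s3)c3c(Cl)cccc32)c1` gives >= 226 ug/mL, which is a limit of the assay rather than a number. Compound 2 `CC(=O)NCc1cccc(Cn2nc(NS(=O)(=O)c3ccc(Cl)s3)c3c(O)cccc32)c1` gives >= 166 ug/mL, again only a limit. Compound 3 `COc1cccc2c1c(NS(=O)(=O)c1ccc(Cl)s1)nn2Cc1cccc(CNC(=O)C2COC2)c1` gives >= 173 ug/mL, also a limit. Among the measured compounds shown here, the single measured step between neighbours, a step that the two limits leave unreadable from compound 1 to compound 2, cannot be read in size, since both of its ends are limits. Compound 3 thus sits where the other two sit: at a limit, with the two further values shown being limits as well.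

Compound 4 `CN[C@H](C)C(=O)NCc1cccc(Cn2nc(NS(=O)(=O)c3ccc(Cl)s3)c3c(OC)cccc32)c1` differs from compound 3 by 1-(methylamino)ethyl in place of oxetan-3-yl on a carbonyl carbon. No measured step covers this change, and the one step that is shown has no readable size, so nothing here supports expecting a move beyond the scatter in this assay in either direction. Compound 4 is therefore expected to give about 180 ug/mL, estimated between 100 ug/mL and 260 ug/mL, most likely reported once more as a limit only. The implied step that the limit leaves unreadable from compound 3 to compound 4 is expected to remain within the scatter.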

Compound 4, solubility: 191 ug/mL
Compound 4: middle estimate off by 1.1-fold (0.03 log units), on the low side; the measured number falls inside the stated range.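

In this assay compound 3 gives >= 173 ug/mL, which is a limit and not a number. Its step to compound 4, which gives 191 ug/mL, cannot be read in size. The compounds shown leave open how 1-(methylamino)ethyl and oxetan-3-yl truly compare on this carbonyl carbon.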